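The source may hold more compounds than are shown below. What is called first, only, known or untested is meant among the compounds shown, and "the series" means these compounds.

Of the compounds shown here, three sharing one core have been measured in a functional assay on Caco-2 cells (Homo sapiens), read by fluorescence and BrdU incorporation, with a stated time of 48 h, tested at 10 uM; a lower number here means a stronger effect, a higher number a weaker effect of the compound at the concentration tested. Compound 2 `COc1cc(OC)c(C(=O)/C=C/c2ccccc2SC)c(OC)c1` gives 36%, the lowest of the three numbers. Compound 3 `COc1cc(O)c(C(=O)/C=C/c2ccccc2OC)c(OC)c1` gives 46%, a number that sits within the usual scatter of compound 2, so the two cannot be ranked. Compound 1 `COc1cc(O)c(C(=O)/C=C/c2ccc(F)cc2)c(OC)c1` gives 49%, which lies beyond the scatter of compound 2, so compound 2 has the stronger effect in that pair. Among the compounds with values here, compound 1 and compound 3 each differ from compound 2 in more than one place, so no single step between measured compounds is available.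

Compound 4 `COc1cc(OC)c(C(=O)/C=C/c2ccc(Cl)cc2)c(OC)c1` has not been measured. It differs from compound 2 in one place: 4-chlorophenyl in place of 2-(methylsulfanyl)phenyl on a double-bonded chain carbon bound to a double-bonded chain carbon. Within the data shown here, nothing among the measured compounds shows what this exchange does on its own. Compound 1 also carries a halogen on its ring and gives 49%, the highest number of the three, but its core differs as well, so it offers only a hint. On that hint, compound 4 is expected to show a small step towards a higher number, a number 9 percentage points higher from compound 2 to compound 4 (within the scatter), possibly within the scatter. The estimate for compound 4 in this assay is 45%, with a range from 30% to 65%.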

Compound 4, a percentage reported as activity, at one concentration (the size of the read-out at that concentration, not a potency): 39%
The estimate for compound 4 lay 6 percentage points above the measured number; measured number inside the range.
By their numbers in this assay, from the lowest: compounds 2, 4, 3 and 1 (each within the scatter of the next, the first and the last beyond it).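

Within the data shown here, replacing 2-(methylsulfanyl)phenyl with 4-chlorophenyl on a double-bonded chain carbon bound to a double-bonded chain carbon gives the first one-place comparison in this assay, with a number 3 percentage points higher from compound 2 to compound 4 (within the scatter). The two compounds therefore cannot be ranked: at this position, the exchange loses the sulfur and the one hydrogen-bond acceptor of the leaving group and brings in a chlorine, yet it produces no readable difference at the concentration tested. No measurement of any property of these groups bears on this result.

This single pair cannot show whether the same holds for very different groups at this position, such as a ring carrying an amine or a carboxylic acid, or a longer open carbon chain in place of the ring. The core of compound 1 and compound 3 also carries a hydroxyl where compound 2 and compound 4 carry a methoxy, and no pair shown here isolates that difference, so its effect on the read-out remains open.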